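The compounds below may be only part of what the source reports. "The series", "measured", "known", "first", "only" and "open" are said of these compounds alone.

Compound 1 `COc1cc2c(Nc3ccc(C#N)cc3)ncnc2cc1OCCCN(C)Cc1ccccc1`: > 100000 nM (a limit)
Compound 2 `COc1cc2c(Nc3ccc(C#N)cc3)ncnc2cc1OCCCN1CCCC1`: 14400 nM
Compound 3 `COc1cc2c(Nc3ccc(C#N)cc3)ncnc2cc1OCCCN1CCC(C)CC1`: 16600 nM

These three compounds share one core and differ in the amine at the end of the chain. All were tested in a functional assay on DU-145 cells (Homo sapiens) for antiproliferative activity, read by MTT assay, with a stated time of 72 h; a higher number here means a weaker inhibitor, a lower number a stronger inhibitor. Compound 1 gives > 100000 nM, which is a limit of the assay and not a number. Among the measured compounds shown here, compound 2 gives 14400 nM and, with compound 3 at 16600 nM, is one of only two compounds with a measured number. The two lie within the scatter of each other.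

Compound 4 `COc1cc2c(Nc3ccc(C#N)cc3)ncnc2cc1OCCCN1CCCCC1CCO` has not yet been measured. It carries the change (2-(2-hydroxyethyl)piperidin-1-yl in place of pyrrolidin-1-yl on a saturated chain carbon, three bonds along the chain from an oxygen on an aromatic ring), with 2-(2-hydroxyethyl)piperidin-1-yl in place of pyrrolidin-1-yl on a saturated chain carbon, three bonds along the chain from an oxygen on an aromatic ring.

For the measured compounds named here, the closest precedent is compound 3, where placing 4-methylpiperidin-1-yl at the same carbon gave a 1.2-fold higher number from compound 2 to compound 3 (0.06 log units; within the scatter). The steps of an at least 6.9-fold lower number from compound 1 to compound 2 (0.84 log units; beyond the scatter) and an at least 6.0-fold lower number from compound 1 to compound 3 (0.77 log units; beyond the scatter) are larger, but both start from a limit and both remove benzyl(methyl)amino, so they bear less directly on this change. Going by the values given here, no measured compound carries the 2-hydroxyethyl group, which keeps the range wide.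

The expected step is a 1.0-fold higher number from compound 2 to compound 4 (0.02 log units; within the scatter), so no change beyond the scatter is expected in this assay. For compound 4 the estimated value is 15000 nM, with an expected range from 5000 nM to 50000 nM.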

Compound 4, half-maximal inhibitory concentration: > 100000 nM
Compound 4 gave a limit, no number (the forecaster's own chance of this, stated with the estimate: 15%); at least 6.6-fold (0.82 log units) between middle value and limit.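

Compound 2 and compound 3 had suggested that this carbon tolerates a change of ring amine in this assay, with pyrrolidin-1-yl and 4-methylpiperidin-1-yl lying within the scatter of each other. Compound 4 shows that this tolerance does not reach 2-(2-hydroxyethyl)piperidin-1-yl, with an at least 6.9-fold higher number from compound 2 to compound 4 (0.84 log units; beyond the scatter) and an at least 6.0-fold higher number from compound 3 to compound 4 (0.77 log units; beyond the scatter), and since compound 3 also carries a six-membered ring, ring size alone does not account for the step from that compound. Compound 4 sits at a limit of the assay, so these two steps give only a minimum size, and the step that joins it to compound 1, also at a limit, cannot be read: the limit of > 100000 nM in this assay, at which 2 of the 4 values shown sit.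

The compounds shown leave open whether the step follows the hydroxyl of the side chain, the length of that chain or its attachment at the 2-position of the piperidine ring, and 2-methylpiperidin-1-yl and 4-(2-hydroxyethyl)piperidin-1-yl at the same carbon would help to separate these. They also leave open how a ring amine with a second nitrogen, such as 4-methylpiperazin-1-yl, would compare with compound 2 and compound 3.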